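The compounds below may be only part of what the source reports. "The series", "measured", "known", "first", "only" and "open" are said of these compounds alone.

Measured so far:
Compound 1, `CCCCn1c(CCC)nc2cc(N)ccc21`: 18200000 nM
Compound 2, `CCCCCCn1c(CCC)nc2cc(NS(C)(=O)=O)ccc21`: 5100000 nM

Of the compounds shown here, two sharing one core have been measured. In a functional assay, read by spectrophotometry, in phosphate buffer, with a stated time of 20 min, at pH 6.6 (on this read-out higher numbers stand for an effect only at larger amounts of compound and lower numbers for an effect already at smaller amounts), compound 1 gives 18200000 nM, while in this assay compound 2 gives 5100000 nM. Of these two numbers, that of compound 2 is the lower one, and the gap to compound 1 lies beyond the usual scatter. Among the measured compounds shown here, compounds 1 and 2 differ in two places at once, the chain on the ring nitrogen and the group on the other nitrogen, so no single step between them can be read off.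

Compound 3, `CCCCCCn1c(CCC)nc2cc(N)ccc21`, keeps the chain of compound 2 and differs from it in one place only: hydrogen in place of methylsulfonyl on a nitrogen on an aromatic ring. The same difference, cut one bond further out, reads methanesulfonamido to amino. For the measured compounds named here, with no measured pair separating this change from the chain change, the expected step from compound 2 to compound 3 is a moderate rise in number, likely beyond the scatter, a 2.4-fold higher number from compound 2 to compound 3 (0.37 log units; beyond the scatter). Compound 3 is therefore expected to give 12000000 nM in this assay, within a range from 4000000 nM to 35000000 nM.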

Compound 3, half-maximal effective concentration: 10300000 nM
Compound 3: the middle estimate sits 1.2-fold (0.07 log units) above what was measured, within the range that was stated.
By their numbers in this assay, from the lowest: compound 2; then compounds 3 and 1 (each within the scatter of the next).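

In this assay, compound 3 lets the two places in which compound 1 and compound 2 differ be read apart: with the chain of compound 2 held fixed, hydrogen in place of methylsulfonyl on the nitrogen on the aromatic ring gives a 2.0-fold higher number from compound 2 to compound 3 (0.31 log units; beyond the scatter), a modest step but the only one of the two that lies beyond the scatter. With the amino group held fixed, ethyl in place of hydrogen on a saturated chain carbon, four bonds along the chain from an aromatic nitrogen, gives a 1.8-fold lower number from compound 1 to compound 3 (0.25 log units; within the scatter), so in this pair the chain difference cannot be told apart from the scatter. Nothing measured alongside these numbers speaks to the reason for either step.

As far as these compounds go, whether the step belongs to methylsulfonyl in particular, or would also appear with an acetyl group or a larger sulfonyl group on that nitrogen, stays open, as does whether it would hold on the shorter chain of compound 1. The compounds shown also leave open how a chain longer than that of compound 3, or one ending in a carboxylic acid or an amine, would read.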